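Replacing pyridin-3-yl in compound 3

This account rests on a few compounds, and the source may have more. Where it says the series, first, only, none or still open, it means among the compounds named here.

Measured in a functional assay on cardiac atrium (Cavia porcellus); on this read-out higher numbers stand for an effect only at larger amounts of compound and lower numbers for an effect already at smaller amounts
Compound 1 `COC(=O)C1=C(C)NC(C)=C(C(=O)OC)C1c1c(-c2cccnc2)nc2sc(C)cn12` gives 12500 nM
Compound 2 `COC(=O)C1=C(C)NC(C)=C(C(=O)OC)C1c1c(-c2ccccn2)nc2sccn12` gives 24400 nM
Compound 3 `COC(=O)C1=C(C)NC(C)=C(C(=O)OC)C1c1c(-c2cccnc2)nc2sccn12` gives 28400 nM

Compound 3 stands within the scatter of compound 2, as a 1.2-fold higher number from compound 2 to compound 3 (0.07 log units; within the scatter) shows, and apart from compound 1, as a 2.3-fold higher number from compound 1 to compound 3 (0.36 log units; beyond the scatter) shows. Compound 4 `COC(=O)C1=C(C)NC(C)=C(C(=O)OC)C1c1c(-c2c(Cl)csc2Cl)nc2sccn12` changes the group that the first of these steps also changed: a group of 7 heavy atoms (4 carbon, 1 sulfur, 2 chlorine; one five-membered aromatic ring with 1 hetero atom) in place of a group of 6 heavy atoms (5 carbon, 1 nitrogen; one six-membered aromatic ring with 1 hetero atom), on an aromatic carbon. That step swapped one pyridinyl group for another, so it says little about a five-membered ring carrying chlorine. The second step, modest in size, lies at another place. In this assay a modest move to a lower number is therefore expected, with no change also plausible. The expected step is a 2.6-fold lower number from compound 3 to compound 4 (0.41 log units; beyond the scatter). Compound 4 is estimated at 11000 nM, with an expected range from 2000 nM to 38000 nM.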

Compound 4, half-maximal effective concentration: 2160 nM
For compound 4 the middle estimate is 5.1-fold (0.71 log units) above the measured one; the range from low to high includes it.
By their numbers in this assay, from the lowest: compound 4; then compounds 1, 2 and 3 (each within the scatter of the next, the first and the last beyond it).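

In this assay, the aromatic carbon next to the ring nitrogen proves far more sensitive to its group than the swap between pyridinyl groups suggested. The chlorine-bearing five-membered aromatic ring gives (a 13-fold lower number from compound 3 to compound 4 (1.12 log units; beyond the scatter)) in place of pyridin-3-yl and (an 11-fold lower number from compound 2 to compound 4 (1.05 log units; beyond the scatter)) in place of pyridin-2-yl. No measurement at hand accounts for the size of these steps.

What the compounds leave open is whether the chlorine or the five-membered ring carries this change, and whether a phenyl group, a chlorophenyl group or an amine at this place would follow it.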